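The source may report more compounds than this note shows. Statements on the series, on what has been measured and on what is new or still open speak of the compounds shown alone.

Working notes. In an assay on HEK293 cells for displacement of a labelled ligand from 5-hydroxytryptamine receptor 6 (Homo sapiens), with a stated time of 60 min, tested at 0.01 uM, in the presence of a further agent that is not named here (a lower number here means a weaker effect, a higher number a stronger effect of the compound at the concentration tested), compound 1 `COc1cc(N)c(Cl)cc1C(=O)CCC1CCN(CCNS(=O)(=O)c2ccc(C)cc2)CC1` is recorded as "not active" (no number reported), with no number given. Among the compounds with values here, compound 2 `COc1cc(N)c(Cl)cc1C(=O)CCC1CCN(CCNS(=O)(=O)c2ccc(N)c(Br)c2)CC1` is the only compound of the pair with a number: in this assay compound 2 gives 39%. Compound 3 `COc1ccc(S(=O)(=O)NCCN2CCC(CCC(=O)c3cc(Cl)c(N)cc3OC)CC2)c(OC)c1` has not been measured; it differs from compound 2 by 2,4-dimethoxyphenyl in place of 4-amino-3-bromophenyl on a sulfonyl sulfur. Within the data shown here, no step between measured compounds exists to size this change; the expectation for compound 3 in this assay is a step downward from compound 2, likely near the edge of the scatter, a number 14 percentage points lower from compound 2 to compound 3 (beyond the scatter). Compound 3 is therefore estimated to give 25%, within a range from 5% to 50%.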

Compound 3, a percentage reported as inhibition, at one concentration (the size of the read-out at that concentration, not a potency): "not active" (no number reported)
Nothing numeric was reported for compound 3; there is nothing to compare the estimate with.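

In this assay, within the data shown here, compound 3 gives "not active" (no number reported) and so no step from compound 2 can be read. The compounds shown leave open whether the amino group or the bromine of 4-amino-3-bromophenyl matters for the read-out of compound 2. No measured evidence on a cause is at hand.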